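The compounds below may be only part of what the source reports. "The series", "measured", "known", "first", "only" and "open" are said of these compounds alone.

Compound 1 `Cc1cccc(/C(CCN2CCN(c3ccccn3)CC2)=N/O)c1` and compound 2 `N#Cc1cccc(/C(CCN2CCN(c3ccccn3)CC2)=N/O)c1` share one core and differ in a single place, (methyl in place of cyano on an aromatic carbon). In a functional assay on HEK293 cells with D(4) dopamine receptor (Homo sapiens) as the target, read by FLIPR (a higher number here means a larger maximal response, a lower number a smaller maximal response), compound 2 gives 48%, while compound 1 gives 74%, so the exchange produced a number 26 percentage points higher from compound 2 to compound 1 (beyond the scatter).

Compound 3 `CCO/N=C(\CCN1CCN(c2ncccc2C#N)CC1)c1ccccc1` is built on a different core; how its core differs from that of compound 2 is not broken down here. In this assay compound 3 gives 64%, which sits within the scatter of compound 1 and beyond it relative to compound 2.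

Compound 4 `CCO/N=C(\CCN1CCN(c2ncccc2C)CC1)c1ccccc1` has not yet been measured. It differs from compound 3 by methyl in place of cyano on an aromatic carbon. Among the compounds with values here, this is the same kind of change as the one between compound 2 and compound 1, not the same change: there the place was on a six-membered aromatic ring of carbon only, meta to a large group, whereas here it is on a six-membered aromatic ring with one nitrogen, ortho to a large group and two atoms from the ring nitrogen. Because a number 26 percentage points higher from compound 2 to compound 1 (beyond the scatter) was gained on the other core, a step of similar direction but tempered size, a number 16 percentage points higher from compound 3 to compound 4 (beyond the scatter), is expected here. Compound 4 is thus estimated at 80%, with a range from 62% to 98%.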

Compound 4, largest response reached (reported as efficacy), in percent of the reference or control that the assay uses: 49%
For compound 4 the middle estimate is 31 percentage points above the measured one; the measured number lies below the stated range.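

In this assay, the exchange of 3-cyanopyridin-2-yl for 3-methylpyridin-2-yl produced a number 15 percentage points lower from compound 3 to compound 4 (beyond the scatter), so methyl in place of cyano did not keep on this core the direction it had on the core of compound 1. The two steps run opposite ways, and the gap between them is larger than repeated measurements would explain: the same change on two cores in this assay, a number 26 percentage points higher (beyond the scatter) from compound 2 to compound 1 and a number 15 percentage points lower (beyond the scatter) from compound 3 to compound 4, 41 percentage points apart, beyond the scatter of two such steps This shows that the outcome of this exchange cannot simply be carried from one core to the other in this series, but two pairs give no rule, and they do not show whether the reversal comes from the ring bearing the change, the place on that ring, or the rest of the core.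

The compounds shown leave open how a methoxy group or a chlorine atom at either place would compare with cyano and methyl. They also leave open whether the reversal would persist if cyano and methyl were exchanged on a core that differs from compound 3 only in a longer chain on the oxime oxygen.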